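The source may hold more compounds than are shown below. What is called first, only, known or untested is meant among the compounds shown, and "the series" means these compounds.

Compound 1 `COC(=O)[C@@]1(C)CCC=C2[C@@H]1CC[C@@H](C)[C@]2(C)Cc1c[nH]c2ccccc12`: 5000 nM in a functional assay on A549 cells (Homo sapiens) for inhibition, read by sulforhodamine B assay, with a stated time of 48 h; on this read-out lower numbers stand for stronger inhibition of growth and higher numbers for weaker inhibition of growth
Compound 2 `COC(=O)[C@@]1(C)CCC=C2[C@@H]1CC[C@@H](C)[C@]2(C)Cc1c[nH]c2ccc(C(F)(F)F)cc12`: 15000 nM

Compound 1 stands at the lower of the two numbers in this assay, with compound 2 the nearest at a 3.0-fold higher number from compound 1 to compound 2 (0.48 log units; beyond the scatter). Compound 3 `COC(=O)[C@@]1(C)CCC=C2[C@@H]1CC[C@@H](C)[C@]2(C)Cc1c(C)[nH]c2ccccc12` differs from compound 1 by methyl in place of hydrogen on an aromatic carbon. Within the data shown here, no measured step touches this position; the only step known, from compound 1 to compound 2, alters the six-membered part of the same ring system and was modest. Compound 3 is therefore expected to stay close to compound 1, with an estimated step of a 1.2-fold higher number from compound 1 to compound 3 (0.08 log units; within the scatter) and no change beyond the scatter. The estimate for compound 3 is 6000 nM, ranging from 2500 nM to 15000 nM.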

Compound 3, concentration for 50% growth inhibition: 15000 nM
Beside the measured number, compound 3's estimate is 2.5-fold (0.40 log units) below it; the measured number falls inside the stated range.
By their numbers in this assay, from the lowest: compound 1; then compounds 2 and 3 (each within the scatter of the next).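

In this assay, the aromatic carbon next to the ring nitrogen proves sensitive to substitution: methyl in place of hydrogen there gives a 3.0-fold higher number from compound 1 to compound 3 (0.48 log units; beyond the scatter) and so weakens growth inhibition. The trifluoromethyl step in the six-membered part, a 3.0-fold higher number from compound 1 to compound 2 (0.48 log units; beyond the scatter), runs the same way, so among these compounds both substitutions raise the number and neither goes against this. Nothing available explains the effect of the methyl group.

On these data alone, whether a longer chain, an amine or a carboxylic acid at this carbon would raise the number further or return it toward that of compound 1 remains open.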